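The compounds below may be only part of what the source reports. "The series", "measured", "known", "first", "only" and "open" are said of these compounds alone.

Measured in a functional assay on MCF7 cells (Homo sapiens) for antiproliferative activity, read by MTT assay, with a stated time of 72 h; a higher number here means a weaker inhibitor, a lower number a stronger inhibitor:
- Compound 1 `CC1=CC[C@H]2[C@H](CC[C@]2(C)O)C(C)(C)[C@@H]1CC[C@H]1[C@]2(C)CC[C@H](OC(=O)c3ccc(C)cc3)C(C)(C)O[C@H]2CC[C@@]1(C)O`: > 50000 nM, a limit of the assay and not a number
- Compound 2 `CC1=CC[C@H]2[C@H](CC[C@]2(C)O)C(C)(C)[C@@H]1CC[C@H]1[C@]2(C)CC[C@H](OC(=O)c3ccc(Cl)c(Cl)c3)C(C)(C)O[C@H]2CC[C@@]1(C)O`: 11900 nM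
- Compound 3 `CC1=CC[C@H]2[C@H](CC[C@]2(C)O)C(C)(C)[C@@H]1CC[C@H]1[C@]2(C)CC[C@H](OC(=O)c3cccc([N+](=O)[O-])c3)C(C)(C)O[C@H]2CC[C@@]1(C)O`: 36000 nM

Compound 3 holds the higher of the two true numbers, a gap shown by the step of a 3.0-fold higher number from compound 2 to compound 3 (0.48 log units; beyond the scatter). Compound 4 `CC1=CC[C@H]2[C@H](CC[C@]2(C)O)C(C)(C)[C@@H]1CC[C@H]1[C@]2(C)CC[C@H](OC(=O)c3cccc(C(F)(F)F)c3)C(C)(C)O[C@H]2CC[C@@]1(C)O` carries trifluoromethyl in place of nitro on an aromatic carbon. Among the compounds with values here, no measured step makes this exact swap, but the measured compounds differ only in the aromatic group on the same carbonyl. The closest guides are an at least 4.2-fold lower number from compound 1 to compound 2 (0.62 log units; beyond the scatter) and an at least 1.3-fold lower number from compound 1 to compound 3 (0.14 log units; that floor lies within the scatter), along with the gap above. On that basis, a small step toward a lower number, perhaps none beyond the scatter, is expected in this assay. For compound 4 the estimate is 21000 nM, with an expected range of 9000 nM to 48000 nM. This estimate means an expected 1.7-fold lower number from compound 3 to compound 4 (0.23 log units; within the scatter).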

Compound 4, half-maximal inhibitory concentration: 37900 nM
The estimate for compound 4 lay 1.8-fold (0.26 log units) below the measured number, and the stated range covers the measured number.
By their numbers in this assay, from the lowest: compound 2; then compounds 3 and 4 (each within the scatter of the next). At a limit, above all of these: compound 1.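

Swapping nitro for trifluoromethyl on this aromatic carbon, meta to a large group, makes no difference beyond the scatter in this assay (a 1.1-fold higher number from compound 3 to compound 4 (0.02 log units; within the scatter)). The 3,4-dichlorophenyl group keeps the lower number against this new group too (a 3.2-fold higher number from compound 2 to compound 4 (0.50 log units; beyond the scatter)). The comparison with the 4-methylphenyl group gives only a floor (an at least 1.3-fold lower number from compound 1 to compound 4 (0.12 log units; that floor lies within the scatter)), and its true size cannot be read: the limit of > 50000 nM in this assay, at which 1 of the 4 values shown sits.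

From the compounds shown here alone, what an amine or a methoxy group would do at this same place stays open. So does whether a single chlorine would match the 3,4-dichlorophenyl group.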